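Cytotoxicity of Modified Nucleoside Analogues: Amide Side-Chain Variation

The compounds below may be only part of what the source reports. "The series", "measured", "known", "first", "only" and "open" are said of these compounds alone.

Measured compounds:
compound 1, `Cc1cn([C@@H]2O[C@H](CO[Si](C)(C)C(C)(C)C)[C@@]3(OS(=O)(=O)C=C3NC(=O)c3ccccc3)[C@H]2O[Si](C)(C)C(C)(C)C)c(=O)n(C)c1=O`: 9700 nM
compound 2, `Cc1cn([C@@H]2O[C@H](CO[Si](C)(C)C(C)(C)C)[C@@]3(OS(=O)(=O)C=C3NCC(=O)C(N)=O)[C@H]2O[Si](C)(C)C(C)(C)C)c(=O)n(C)c1=O`: 14500 nM

Both compounds were tested in a functional assay on HEL cells (Homo sapiens); on this read-out lower numbers stand for higher toxicity in this test and higher numbers for lower toxicity in this test. Compound 2 shows the highest number of the two; its nearest neighbour is compound 1, with a 1.5-fold higher number from compound 1 to compound 2 (0.17 log units; within the scatter), so the two cannot be told apart on this read-out.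

Compound 3 is `Cc1cn([C@@H]2O[C@H](CO[Si](C)(C)C(C)(C)C)[C@@]3(OS(=O)(=O)C=C3NCC(=O)OCc3ccccc3)[C@H]2O[Si](C)(C)C(C)(C)C)c(=O)n(C)c1=O`. It differs from compound 2 in one place: benzyloxy in place of carbamoyl on a carbonyl carbon.

Going by the values given here, the single measured step that bears on this change is the swap on the amine nitrogen, a 1.5-fold higher number from compound 1 to compound 2 (0.17 log units; within the scatter), which did not move the number beyond the scatter. Compound 1 already carries an aromatic ring at this end of the chain, as compound 3 will, and its number lies within the scatter of compound 2. No step beyond the scatter is therefore expected in this assay .

Compound 3 is estimated to give 12000 nM (range 5000 nM to 30000 nM), which corresponds to an expected 1.2-fold lower number from compound 2 to compound 3 (0.08 log units; within the scatter).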

Compound 3, half-maximal cytotoxic concentration: > 200000 nM
Compound 3: only a limit was reported (the forecaster's own chance of this, stated with the estimate: 10%); at least 16-fold (1.22 log units) between middle value and limit.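

In this assay compound 3 gives only a limit of the assay, > 200000 nM, not a number. Going by these compounds alone, the group on this carbonyl carbon therefore matters in this test, which the earlier pair did not show: benzyloxy in place of carbamoyl gives an at least 13-fold higher number from compound 2 to compound 3 (1.13 log units; beyond the scatter), whereas the first swap on the amine nitrogen stayed within the scatter. An aromatic ring alone does not settle the outcome, since compound 1 also carries one, in its benzoyl group, and the change to the (benzyloxycarbonyl)methyl group still gives an at least 20-fold higher number from compound 1 to compound 3 (1.31 log units; beyond the scatter).

Going by these compounds, the true size of the step stays unknown because the reading for compound 3 stops at a limit: the limit of > 200000 nM in this assay, at which 1 of the 3 values shown sits. It also remains open whether this step goes with the oxygen or the ring of benzyloxy; a methoxy or a hydroxy group on the same carbonyl carbon would help to separate the two.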